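The source may hold more compounds than are shown below. What is called first, only, known or untested is meant among the compounds shown, and "the series" means these compounds.

Compound 1 `COc1ccc(OC)c(S(=O)(=O)NC(=O)c2ccc(Cn3ccc4ccc(NC(=O)CC5CCCC5)cc43)c(OC)c2)c1` is an acylsulfonamide carrying a 2,5-dimethoxyphenyl group on its sulfonyl sulfur. In a functional assay (trachea) for antagonist activity, with Cavia porcellus as the target (a higher number here means a more potent compound, by a factor of ten per unit of this negative logarithm, a lower number a less potent compound), compound 1 gives 9.1. Of the two numbers recorded so far this is the lower one, but only by a margin that falls inside the usual scatter: compound 2 `CCCCOC(=O)Nc1ccc2cnn(Cc3ccc(C(=O)NS(=O)(=O)c4ccccc4)cc3OC)c2c1`, which carries a plain phenylsulfonyl group on a different core, gives 9.2 in this assay, so the two compounds cannot be placed in order on these numbers.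

Compound 3 `COc1cc(C(=O)NS(=O)(=O)c2ccccc2Cl)ccc1Cn1ccc2ccc(NC(=O)CC3CCCC3)cc21` differs from compound 1 in one place: 2-chlorophenyl in place of 2,5-dimethoxyphenyl on a sulfonyl sulfur. Going by the values given here, no measured pair shows what such an exchange on the sulfonyl sulfur does in this assay, so the step has to be guessed from the two values at hand. Since compound 2 with an unsubstituted aryl group on the sulfonyl gives 9.2, a large loss from removing the two methoxy groups seems unlikely, and a step of a number 0.10 log units lower from compound 1 to compound 3 (within the scatter) is expected, that is, no change beyond the scatter. For compound 3 in this assay a value of 9 is estimated, within a range from 8.4 to 9.6.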

Compound 3, negative logarithm of the antagonist equilibrium constant: 9.8
For compound 3 the middle estimate is 0.80 log units below the measured one, outside the stated range (above it).
By their numbers in this assay, from the lowest: compounds 1 and 2 (each within the scatter of the next); then compound 3.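

The sulfonyl sulfur, on which no earlier pair had shown a step, turns out not to be indifferent to its aryl group: in this assay the exchange of 2,5-dimethoxyphenyl for 2-chlorophenyl amounts to a number 0.70 log units higher from compound 1 to compound 3 (beyond the scatter) on an otherwise unchanged structure. The two hydrogen-bond acceptors of the group that leaves are therefore not needed for a high number in this series, since the 2-chlorophenyl group has none and compound 3 still stands above compound 1. Nothing measured on these compounds accounts for the rise, so the step remains an observation without an explanation.

A single exchange also cannot separate what the chlorine contributes from what the loss of the two methoxy groups contributes, since both happen in the same step. From the compounds shown here alone, it remains open whether a bromine atom or a methyl group in place of the chlorine would keep this gain, and whether a pyridine ring on the sulfonyl sulfur would be tolerated on the core of compound 1.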